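The compounds below may be only part of what the source reports. "The series", "measured", "known", "first", "only" and "open" are said of these compounds alone.

In a functional assay on A549 cells (Homo sapiens) for antiproliferative activity, read by sulforhodamine B assay, with a stated time of 3 days (a lower number here means that less compound is needed, a higher number that more compound is needed for the effect), compound 1 (`CCCC1=C(OCCC(C)C)C(CCC)(CCC)C(=O)/C(=C(O)\C=C\c2ccccc2)C1=O`) gives 11.3 uM. Compound 2 (`COC1=C(CC=C(C)C)C(=O)/C(=C(O)/C=C/c2ccccc2)C(=O)C1(CC=C(C)C)CC=C(C)C`) gives 10.3 uM. For the measured compounds named here, these two values lie within the scatter of each other, so compound 1 stands level with the only other measured compound.

Compound 3 (`CCCC1=C(OCC)C(CCC)(CCC)C(=O)/C(=C(O)\C=C\c2ccccc2)C1=O`) keeps the core of compound 1 and alters a single group, with isopentyloxy giving way to ethoxy. The counted difference is hydrogen in place of isopropyl on a saturated chain carbon, two bonds along the chain from an oxygen on an unsaturated carbon. In words, this is hydrogen in place of isopropyl on a saturated chain carbon, two bonds along the chain from an oxygen on an unsaturated carbon.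

Going by the values given here, no measured pair isolates this change, and compound 2 differs from compound 1 in more than one place, so the data offer only a loose frame. Even so, the two structurally different compounds sit close together, which argues against expecting a large move. A small shift in this assay towards a higher number is expected, if any shift emerges beyond the scatter. The estimated step is a 1.2-fold higher number from compound 1 to compound 3 (0.09 log units; within the scatter). Compound 3 is expected at 14 uM, with an estimated range of 7 uM to 28 uM.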

Compound 3, concentration for half-maximal effect: 4.6 uM
The estimate for compound 3 lay 3.0-fold (0.48 log units) above the measured number, outside the stated range (below it).
By their numbers in this assay, from the lowest: compound 3; then compounds 2 and 1 (each within the scatter of the next).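

In this assay, for the compounds shown here, replacing isopropyl with hydrogen on a saturated chain carbon, two bonds along the chain from an oxygen on an unsaturated carbon, gives a 2.5-fold lower number from compound 1 to compound 3 (0.39 log units; beyond the scatter) and is the first single change in this set whose effect can be read directly. It shows that this position is not indifferent to the group it carries: on the shared core, the ethoxy compound needs less compound for the effect than the isopentyloxy compound, by a step beyond the scatter. No measurement shown here bears on why the number falls, so the step stands as an observation without an explanation.

On these data alone, a single pair fixes only two points at this position, so it remains open whether a propoxy or butoxy chain would give a number closer to that of compound 1 or to that of compound 3. As far as these compounds go, it also remains open how an amine or a carboxylic acid in place of the isopropyl would read in this assay, and whether the same change would give a similar step on the core of compound 2.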